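The source may hold more compounds than are shown below. What is called first, only, known or untested is meant among the compounds shown, and "the series" means these compounds.

Compound 1 `C=C1[C@H](OC(=O)c2ccccc2)[C@H]2[C@@H](OC(C)=O)[C@@H](C)C[C@]2(OC(C)=O)C(=O)[C@@H](C)/C=C/C(C)(C)C(=O)[C@H](O)[C@H]1OC(C)=O` and compound 2 `C=C1[C@H](OC(C)=O)[C@H]2[C@@H](OC(=O)c3ccccc3)[C@@H](C)C[C@]2(OC(C)=O)C(=O)[C@@H](C)/C=C/C(C)(C)C(=O)[C@H](O)[C@H]1OC(C)=O` are built from the same atoms joined differently; the difference between the two cores is not broken down here. In an ADME assay on NCI/ADR-RES cells (Homo sapiens) for cytotoxicity, read by MTT assay, with a stated time of 48 h (a higher number here means a weaker inhibitor, a lower number a stronger inhibitor), compound 1 gives only a limit, > 100000 nM. In this assay compound 2 likewise gives only a limit, > 100000 nM. Compound 3 `C=C1[C@H](OC(C)=O)CC(=O)C(C)(C)/C=C/[C@H](C)C(=O)[C@@]2(OC(C)=O)C[C@H](C)[C@H](OC(C)=O)[C@@H]2[C@H]1OC(=O)c1ccccc1` arises from compound 1 by hydrogen in place of hydroxy on a saturated ring carbon. In this assay compound 3 also gives only a limit, > 100000 nM. The step that the two limits leave unreadable from compound 1 to compound 3 cannot be read, since (the limit of > 100000 nM in this assay, at which 3 of the 3 values shown sit). Compound 4 `C=C1[C@H](OC(C)=O)CC(=O)C(C)(C)/C=C/[C@H](C)C(=O)[C@@]2(OC(C)=O)C[C@H](C)[C@H](OC(=O)c3ccccc3)[C@@H]2[C@H]1OC(C)=O` arises from compound 2 by the same kind of change, (hydrogen in place of hydroxy on a saturated ring carbon), the place now lying three ring bonds from the ring atom that bears an acetoxy group rather than a benzoyloxy group. The step that the limit leaves unreadable from compound 2 to compound 4 is expected to remain unreadable in the same way, resting on (the limit of > 100000 nM in this assay, at which 3 of the 3 values shown sit). Compound 4 is accordingly estimated at 150000 nM, most probably again reported only as a limit.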

Compound 4, half-maximal inhibitory concentration: 39300 nM
For compound 4 the middle estimate is 3.8-fold (0.58 log units) above the measured one, and the stated range ends above it.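

In this assay, putting hydrogen in place of hydroxy on the core of compound 2 gives an at least 2.5-fold lower number from compound 2 to compound 4 (0.40 log units; beyond the scatter). From the compounds shown here alone, compound 2 gives only a limit, > 100000 nM, so the true size of this step is unknown. The same change on the core of compound 1 cannot be read, so nothing shows that the gain carries from one core to the other, because both compounds of that pair sit at the limit: the limit of > 100000 nM in this assay, at which 3 of the 4 values shown sit.

Only hydroxy and hydrogen appear on this ring carbon in the compounds shown. Going by these compounds, what an amine or a methoxy group would do at that place remains open, on either core.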